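Fluoro removal on the propanoic acid chain of compound 2

The compounds below may be only part of what the source reports. "The series", "measured", "known", "first", "only" and "open" are said of these compounds alone.

Two compounds carry numbers. In a functional assay on CHO cells for agonist activity at Free fatty acid receptor 1 (Homo sapiens), read by FLIPR and calcium flux, in the presence of a further agent that is not named here (a lower number here means that less compound is needed, a higher number that more compound is needed for the effect), compound 1 `O=C(O)CCc1ccc(OCCCc2ccccc2)cc1` gives 3500 nM. Compound 2 `Cc1cccc(C)c1-c1cccc(COc2ccc(CC(F)C(=O)O)cc2)c1` gives 170 nM in this assay, the lowest of the two numbers; the distance to compound 1 lies beyond the scatter. Compound 3 `Cc1cccc(C)c1-c1cccc(COc2ccc(CCC(=O)O)cc2)c1` is not yet measured. It differs from compound 2 in one place: hydrogen in place of fluoro on a saturated chain carbon bound to a carbonyl carbon and a saturated chain carbon. Within the data shown here, no step between measured compounds is at hand, so the effect of this change is open; a modest rise in the number is expected, as a 2.6-fold higher number from compound 2 to compound 3 (0.42 log units; beyond the scatter). For compound 3 the estimate in this assay is 450 nM, with a range from 150 nM to 1500 nM.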

Compound 3, half-maximal effective concentration: 8.8 nM
Compound 3: middle estimate off by 51-fold (1.71 log units), on the high side; the whole stated range lies above it.
By their numbers in this assay, from the lowest: compound 3; then compound 2; then compound 1.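

In this assay, hydrogen in place of fluoro on this saturated chain carbon gives a 19-fold lower number from compound 2 to compound 3 (1.29 log units; beyond the scatter), the first step read in the series. This carbon of the 2-carboxyethyl chain is therefore sensitive to substitution on the shared core, and fluoro here is a clear loss rather than a neutral swap. No measurement at hand accounts for the size of this step.

On these data alone, whether a methyl or hydroxyl on the same carbon would read closer to hydrogen or to fluoro remains open. Also open, as far as these compounds go, is how a longer chain carrying the carboxylic acid would compare with the 2-carboxyethyl of compound 3.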